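Expected antiproliferative activity of a trifluoromethylphenyl analogue

The source may hold more compounds than are shown below. What is called first, only, known or untested is meant among the compounds shown, and "the series" means these compounds.

Measured compounds:
Compound 1 `COc1cncc(-c2c(C)nn(-c3nc(-c4ccc(Cl)c(Cl)c4)c(SC(C)C)s3)c2C(=O)O)c1`: 21000 nM
Compound 2 `COc1cc(C#N)cc(-c2c(C)nn(-c3nc(-c4ccc(Cl)c(Cl)c4)c(SC(C)C)s3)c2C(=O)O)c1`: 5200 nM

Within the data shown here, in a functional assay on BJAB cells (Homo sapiens) for antiproliferative activity, with a stated time of 4 days (a higher number here means that more compound is needed for the effect, a lower number that less compound is needed), compound 2 gives 5200 nM, the lowest of the two numbers so far. Compound 1 gives 21000 nM in this assay. Among the measured compounds shown here, the single measured step is a 4.0-fold lower number from compound 1 to compound 2 (0.61 log units; beyond the scatter), showing that an exchange of the aryl group at this position can move the number modestly.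

Compound 3 `Cc1nn(-c2nc(-c3ccc(Cl)c(Cl)c3)c(SC(C)C)s2)c(C(=O)O)c1-c1ccccc1C(F)(F)F` carries a different group at the same position: 2-(trifluoromethyl)phenyl in place of 3-cyano-5-methoxyphenyl on an aromatic carbon. For the measured compounds named here, no measured step exchanges these two groups, so the step from compound 1 to compound 2 offers only indirect guidance: it tells that such an exchange can matter, not in which direction. Going by the values given here, with no direct precedent, compound 3 is expected to sit near compound 2, and the estimate is 7000 nM with a range of 1500 nM to 30000 nM. This estimate corresponds to an expected step of a 1.3-fold higher number from compound 2 to compound 3 (0.13 log units; within the scatter).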

Compound 3, half-maximal effective concentration: 5200 nM
Compound 3: the middle estimate sits 1.3-fold (0.13 log units) above what was measured, and the stated range covers the measured number.
By their numbers in this assay, from the lowest: compounds 2 and 3 (each within the scatter of the next); then compound 1.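

In this assay this position accepts two quite different aryl groups with no change at the digits printed from compound 2 to compound 3 (within the scatter) even though 2-(trifluoromethyl)phenyl has no hydrogen-bond acceptors where 3-cyano-5-methoxyphenyl has two, so the nitrile and methoxy groups of compound 2 are not required for its number. The second step, a 4.0-fold lower number from compound 1 to compound 3 (0.61 log units; beyond the scatter) for the same new group in place of 5-methoxypyridin-3-yl, is of the same size as the earlier step from compound 1, which sets both compounds with a carbon-only ring apart from compound 1. Nothing measured here explains why these groups read as they do.

From the compounds shown here alone, all three numbers remain in the micromolar range, so it stays open whether any group at this position can lower the number much further. A phenyl ring carrying an amine or a longer alkoxy chain could still read differently.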